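The compounds below may be only part of what the source reports. "The series", "measured", "known", "first", "only" and "open" are said of these compounds alone.

In an assay on nucleic acid for binding affinity to Nucleic Acid, read by surface plasmon resonance (a higher number here means weaker binding, a lower number tighter binding), compound 1 (`N=C(N)NCCC[C@H](N)C(=O)NCCN[C@H]1[C@@H](O)[C@H](N)C[C@H](N)[C@@H]1O[C@H]1O[C@H](CN)[C@@H](O)[C@H](O)[C@H]1N`) gives 2000 nM and compound 2 (`NCCCC[C@H](N)C(=O)NCCN[C@H]1[C@@H](O)[C@H](N)C[C@H](N)[C@@H]1O[C@H]1O[C@H](CN)[C@@H](O)[C@H](O)[C@H]1N`) gives 1000 nM, two values within the scatter of each other. Compound 3 (`NCCN[C@H]1[C@@H](O)[C@H](N)C[C@H](N)[C@@H]1O[C@H]1O[C@H](CN)[C@@H](O)[C@H](O)[C@H]1N`) differs from compound 2 by hydrogen in place of (1,5-diaminopentyl)carbonyl on an amine nitrogen. Among the compounds with values here, the only measured step, a 2.0-fold lower number from compound 1 to compound 2 (0.30 log units; within the scatter), alters a group within the part that leaves here but does not remove that part, so it bears only loosely on this change. A step towards a higher number, beyond the scatter, is expected in this assay, estimated as a 5.0-fold higher number from compound 2 to compound 3 (0.70 log units; beyond the scatter). For compound 3 the estimated value is 5000 nM, with an expected range from 1500 nM to 15000 nM.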

Compound 3, dissociation constant: 7000 nM
For compound 3 the middle estimate is 1.4-fold (0.15 log units) below the measured one; measured number inside the range.
By their numbers in this assay, from the lowest: compounds 2 and 1 (each within the scatter of the next); then compound 3.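

Taking the (1,5-diaminopentyl)carbonyl group off the amine nitrogen gives a 7.0-fold higher number from compound 2 to compound 3 (0.85 log units; beyond the scatter) and, with the guanidine-bearing version of that side chain, a 3.5-fold higher number from compound 1 to compound 3 (0.54 log units; beyond the scatter) in this assay. Thus, while changing the end of the side chain stayed within the scatter, removing the whole acyl group moved the number beyond it, whichever of the two side chains was lost. The compounds shown leave open whether a simple acetyl group or a shorter amino-acid chain on this nitrogen would keep the lower number. No evidence explains the loss.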